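A Third Compound Beside Two at the Assay Limit

The source may hold more compounds than are shown below. What is called first, only, known or untested is meant among the compounds shown, and "the series" means these compounds.

In a physicochemical assay for solubility, with a stated time of 3 days, at pH 2 (on this read-out lower numbers stand for lower solubility and higher numbers for higher solubility), compound 1 (`NC(=O)c1ccc2[nH]c(-c3ccc(OCC4CCNCC4)cc3)nc2c1`) gives > 400000 nM as a limit of the assay and not as a number. Compound 2 (`Cc1ccc(CN2CCCCC2CCOc2ccc(-c3nc4cc(C(N)=O)ccc4[nH]3)cc2)cc1`) gives > 400000 nM as a limit too, so it has no number of its own. Compound 2 thus stands at the limit of > 400000 nM in this assay, at which 2 of the 2 values shown sit, with no number to rank it by. Compound 3 (`NC(=O)c1ccc2[nH]c(-c3ccc(OCCC4CCCCN4Cc4ccc(Cl)c(Cl)c4)cc3)nc2c1`) has 3,4-dichlorophenyl in place of 4-methylphenyl on a saturated chain carbon bound to an amine nitrogen in a ring when set against compound 2. Among the measured compounds shown here, no measured step shows what this change does in this assay so no shift beyond the usual scatter is expected in either direction. The expected move is a number no higher from compound 2 to compound 3 (the limit leaves the size open) as an estimate only. Compound 3 is estimated at 400000 nM with an expected range of 150000 nM to 800000 nM in this read-out, and it may well be reported as a limit.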

Compound 3, solubility: 39000 nM
For compound 3 the middle estimate is 10-fold (1.01 log units) above the measured one, and the stated range ends above it.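

In this assay the place on a saturated chain carbon bound to an amine nitrogen in a ring now proves able to move the read-out, since 3,4-dichlorophenyl in place of 4-methylphenyl gives an at least 10-fold lower number from compound 2 to compound 3 (1.01 log units; beyond the scatter) and carries compound 3 off the limit. One end of this step is a limit of the assay, so it sets a floor on the size of the change and does not fix that size. Among the compounds shown here, the earlier compounds could show nothing of this kind, and compound 3 is the only one with a number of its own, the others resting at a limit: the limit of > 400000 nM in this assay, at which 2 of the 3 values shown sit.

The compounds shown leave open whether a single chlorine, as in 4-chlorobenzyl, would be enough for such a step. They also leave open whether an unsubstituted benzyl or a pyridylmethyl group at this place would give a number or stay at the limit.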